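This account rests on a few compounds, and the source may have more. Where it says the series, first, only, none or still open, it means among the compounds named here.

In an ADME assay on NHDF cells (Homo sapiens) for cytotoxicity, read by MTT assay, with a stated time of 72 h (on this read-out lower numbers stand for stronger inhibition and higher numbers for weaker inhibition), compound 2 (`COc1ccccc1/C=C1\CCC/C(=C\c2cccc(OC)c2OC)C1=O`) gives 31300 nM and compound 1 (`COc1cccc(/C=C2\CCC/C(=C\c3ccc(Br)cc3)C2=O)c1OC`) gives 21400 nM, two values within the scatter of each other. Compound 3 (`COc1cccc(/C=C2\CCC/C(=C\c3cc(Cl)cc(Cl)c3)C2=O)c1OC`) is the next case, with this change from compound 2: 3,5-dichlorophenyl in place of 2-methoxyphenyl on a double-bonded chain carbon bound to a double-bonded ring carbon. For the measured compounds named here, the only measured step at this place is a 1.5-fold higher number from compound 1 to compound 2 (0.17 log units; within the scatter). That single step gives no ground for expecting a change beyond the scatter in this assay. The estimated step is a 1.6-fold lower number from compound 2 to compound 3 (0.19 log units; within the scatter), which is expected to remain within the scatter. For compound 3 the estimated value is 20000 nM, with an expected range of 9000 nM to 45000 nM.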

Compound 3, half-maximal inhibitory concentration: 21600 nM
Estimate against measurement, compound 3: 1.1-fold (0.03 log units) below, and the stated range covers the measured number.
By their numbers in this assay, from the lowest: compounds 1, 3 and 2 (each within the scatter of the next).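

In this assay, three aryl groups have now been compared on a double-bonded chain carbon bound to a double-bonded ring carbon, and both new steps stay within the scatter: a 1.4-fold lower number from compound 2 to compound 3 (0.16 log units; within the scatter) and a 1.0-fold higher number from compound 1 to compound 3 (0.00 log units; within the scatter). Across compounds 1, 2 and 3, replacing 2-methoxyphenyl or 4-bromophenyl with 3,5-dichlorophenyl therefore gives no separable change at this position. No measured evidence bears on this result. On these data alone, it remains open whether an amine or a carboxylic acid on the aromatic ring at this place would give a step beyond the scatter.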